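Acid stability of the ester series: carbamoyl for cyano

A few compounds are considered here, and "the series" means these few. Any claim that something is new, unique, unknown or untested is made for them only; others in the source may bear on it.

Three measured compounds share the ester-linked acid side chain and differ at the five-membered core. Compound 1 `NC(=O)c1c(CSCC(=O)Oc2ccccc2C(=O)O)no[n+]1[O-]` carries a carbamoyl, compound 2 `N#Cc1c(CSCC(=O)Oc2ccccc2C(=O)O)no[n+]1[O-]` a cyano on the same charged core, and compound 3 `N#Cc1nonc1CSCC(=O)Oc1ccccc1C(=O)O` a cyano on an uncharged core. In a physicochemical assay, read by HPLC, with a stated time of 3 h, at pH 1, tested at 100 uM (a lower number here means that less of the compound is left, a higher number that more of the compound is left), compound 1 gives 97%, compound 2 gives 96% and compound 3 gives 96%. The change carbamoyl in place of cyano on an aromatic carbon produced the step of a number 1 percentage points higher from compound 2 to compound 1 (within the scatter). How the core of compound 3 differs from that of compound 2 is not broken down here; the two values stand level at the digits given.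

Compound 4 `NC(=O)c1nonc1CSCC(=O)Oc1ccccc1C(=O)O` is not yet measured and arises from compound 3 by carbamoyl in place of cyano on an aromatic carbon. This is the same kind of change as from compound 2 to compound 1, not the same: in compound 2 the place is also next to the ring atom that bears a group of 1 heavy atom. A step of about no change at the digits printed from compound 3 to compound 4 (within the scatter) is expected for compound 4 because a number 1 percentage points higher from compound 2 to compound 1 (within the scatter) stayed within the scatter. Compound 4 is therefore estimated at 96%, between 90% and 100%.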

Compound 4, percent of the compound remaining: 97%
Beside the measured number, compound 4's estimate is 1 percentage points below it; the range from low to high includes it.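

In this assay, carbamoyl in place of cyano on an aromatic carbon produced the step of a number 1 percentage points higher from compound 3 to compound 4 (within the scatter) on the uncharged core, and on the charged core it produced the step of a number 1 percentage points higher from compound 2 to compound 1 (within the scatter), so on both cores the swap stays within the scatter. This shows that the swap can be carried between these two cores without a step beyond the scatter in this read-out, but it does not show that the swap acts alike on both, since with so much of every compound left there is little room for a larger step to appear. No measurement shown bears on why the steps take this size.

On these data alone, the series shows only cyano and carbamoyl at this aromatic carbon, so it remains open whether an amine or a carboxylic acid there would stay within the scatter on either core. Also open, as far as these compounds go, is whether a longer chain in place of the present link to the ester would keep these compounds at the same level.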